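Pyridyl swap on the pyrazole chalcones

The source may hold more compounds than are shown below. What is called first, only, known or untested is meant among the compounds shown, and "the series" means these compounds.

Measured so far in a functional assay on HCT-116 cells (Homo sapiens) for inhibition, read by sulforhodamine B assay, with a stated time of 72 h; on this read-out lower numbers stand for stronger inhibition and higher numbers for weaker inhibition:
compound 1 `O=C(/C=C/c1cn(-c2ccccc2)nc1-c1cccnc1)c1cc[nH]c1` gives 7400 nM
compound 2 `COc1cc(OC)c(C(=O)/C=C/c2cn(-c3ccccc3)nc2-c2cccnc2)c(OC)c1` gives 300 nM
compound 3 `O=C(/C=C/c1cn(-c2ccccc2)nc1-c1ccncc1)c1cc[nH]c1` gives 15700 nM

Compound 2 has the lowest number of the three; compound 1 stands nearest with a higher number and compound 3 furthest, both gaps beyond the scatter. The difference between the core of compound 2 and the core of compound 1 is not broken down here.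

One change is seen directly. From compound 1 to compound 3 the change is pyridin-4-yl in place of pyridin-3-yl on an aromatic carbon and the step is a 2.1-fold higher number from compound 1 to compound 3 (0.33 log units; beyond the scatter), a modest rise in the number that lies beyond the scatter.

Compound 4 `COc1cc(OC)c(C(=O)/C=C/c2cn(-c3ccccc3)nc2-c2ccncc2)c(OC)c1` is not yet measured. It relates to compound 2 as compound 3 relates to compound 1: pyridin-4-yl in place of pyridin-3-yl on an aromatic carbon. The two surroundings are not word for word alike, since in compound 1 the place sits next to the ring atom that bears a group of 9 heavy atoms, whereas in compound 2 it sits next to the ring atom that bears a large group; the change is therefore the same kind of change rather than the same one.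

Compound 4 is expected to show a step of about a 2.1-fold higher number from compound 2 to compound 4 (0.32 log units; beyond the scatter) in this assay, on the same side and of roughly the same size as the earlier step, because of a 2.1-fold higher number from compound 1 to compound 3 (0.33 log units; beyond the scatter) and the value of compound 2 at 300 nM. The estimate for compound 4 in this assay is 630 nM, from 300 nM to 1500 nM, and it rests on a single precedent only.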

Compound 4, half-maximal inhibitory concentration: 600 nM
Compound 4: middle estimate off by 1.1-fold (0.02 log units), on the high side; the range from low to high includes it.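

In this assay, putting pyridin-4-yl in place of pyridin-3-yl on the core of compound 2 gives a 2.0-fold higher number from compound 2 to compound 4 (0.30 log units; within the scatter), so on this core taken alone the two pyridyl groups cannot be told apart. Set beside the same change on the core of compound 1, the step carries over from one core to the other on the same side and at a matching size: the same change on two cores in this assay, a 2.1-fold higher number (0.33 log units; beyond the scatter) from compound 1 to compound 3 and a 2.0-fold higher number (0.30 log units; within the scatter) from compound 2 to compound 4, 1.1-fold (0.03 log units) apart, within the scatter of two such steps. This agreement rests on two pairs only, one of them within the scatter, so it does not show that the step is firmly established on the core of compound 2, that it would hold on a third core, or why the two pyridyl groups might differ at all.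

The compounds shown leave open how a pyridin-2-yl group or a plain phenyl group would compare at this place, and whether an amine or a carboxylic acid carried on the pyridyl group would leave the step unchanged. They also leave open whether the step seen in this assay would appear in other cell lines or in any other read-out.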